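Aryl amine swap in compound 2: expected growth inhibition

The source may report more compounds than this note shows. Statements on the series, on what has been measured and on what is new or still open speak of the compounds shown alone.

Values in a functional assay on SF-295 cells (Homo sapiens) for inhibition, read by sulforhodamine B assay, with a stated time of 48 h (on this read-out lower numbers stand for stronger inhibition of growth and higher numbers for weaker inhibition of growth), so far, by compound:
- compound 1 `CN1CCN(CCCOc2cccc3nc(Nc4ccc(Cl)c(C(F)(F)F)c4)ccc23)CC1` gives 1800 nM
- compound 2 `CC(C)c1ccc(Nc2ccc3c(OCCCN4CCN(C)CC4)cccc3n2)cc1` gives 3630 nM
- compound 3 `CN1CCN(CCCOc2cccc3nc(Nc4ccc(F)c(F)c4)ccc23)CC1` gives 4640 nM

Compound 2 sits inside the scatter of both other measured compounds, so it is separated from neither. The two steps read a 2.0-fold higher number from compound 1 to compound 2 (0.30 log units; within the scatter) and a 1.3-fold higher number from compound 2 to compound 3 (0.11 log units; within the scatter). Compound 4 `CN1CCN(CCCOc2cccc3nc(Nc4cc(Cl)cc(Cl)c4)ccc23)CC1` carries 3,5-dichlorophenyl in place of 4-isopropylphenyl on a nitrogen on an aromatic ring. Among the compounds with values here, no measured step covers this exact exchange, so the evidence comes from the other changes of the group at that place. Among these, only a 2.6-fold higher number from compound 1 to compound 3 (0.41 log units; beyond the scatter) goes beyond the scatter, and it is modest. The three measured groups therefore span a narrow range. The expected step is a 1.3-fold lower number from compound 2 to compound 4 (0.11 log units; within the scatter), a slight move towards stronger inhibition of growth that is not expected to clear the scatter in this assay. The estimated value for compound 4 is 2800 nM with an expected range (1300 nM to 6000 nM).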

Compound 4, concentration for 50% growth inhibition: 1720 nM
Compound 4: the middle estimate sits 1.6-fold (0.21 log units) above what was measured; measured number inside the range.
By their numbers in this assay, from the lowest: compounds 4, 1, 2 and 3 (each within the scatter of the next, the first and the last beyond it).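

In this assay, within the data shown here, the 3,5-dichlorophenyl group of compound 4 is the first group at this nitrogen to separate from 4-isopropylphenyl (a 2.1-fold lower number from compound 2 to compound 4 (0.32 log units; beyond the scatter)), and it also separates from 3,4-difluorophenyl (a 2.7-fold lower number from compound 3 to compound 4 (0.43 log units; beyond the scatter)), though both steps are modest. Compound 4 stays level with the 4-chloro-3-(trifluoromethyl)phenyl group of compound 1 (a 1.0-fold lower number from compound 1 to compound 4 (0.02 log units; within the scatter)), so these two chlorine-bearing groups cannot be told apart here. Nothing at hand explains these differences.

All groups shown at this place are substituted phenyl rings, so a cyclohexyl or pyridyl group there, or a carboxylic acid or methoxy on the phenyl ring, remains open. As far as these compounds go, the side chain with its methylpiperazine is also the same throughout, so the effect of a shorter or longer chain on these steps remains open.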